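This account rests on a few compounds, and the source may have more. Where it says the series, first, only, none or still open, it means among the compounds named here.

Measured compounds:
Compound 1, `COC(=O)[C@@H]1C[C@@]2(CC=C(C)C)c3ccccc3N3C(=N)C(C)(C)N1[C@H]32`: 5660 nM
Compound 2, `COC(=O)[C@@H]1C[C@@]2(CC=C(C)C)c3ccccc3N3C(=N)[C@H](Cc4ccccc4)N1[C@H]32`: 22100 nM

In a functional assay on A549 cells (Homo sapiens) for cytotoxicity, read by sulforhodamine B assay, with a stated time of 48 h (on this read-out lower numbers stand for stronger inhibition of growth and higher numbers for weaker inhibition of growth), compound 1 gives 5660 nM, while compound 2 gives 22100 nM. For the measured compounds named here, compound 2 thus stands at the highest of the two numbers, and its only neighbour, compound 1, sits at a clearly lower number, a gap that lies beyond the usual scatter of repeated measurements.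

Compound 3, `COC(=O)[C@@H]1C[C@@]2(CC=C(C)C)c3ccccc3N3C(=N)[C@H](C(C)(C)C)N1[C@H]32`, has not yet been tested in this assay. Compared with compound 2 it carries tert-butyl in place of benzyl on a saturated ring carbon, that is, tert-butyl in place of benzyl on a saturated ring carbon of a five-membered non-aromatic ring with 2 nitrogen. Going by the values given here, no pair of measured compounds shares this exact change, so any expectation rests only on the fact that compound 1, which carries no benzyl, gives the lower of the two numbers in this assay. On that basis compound 3 is expected to move toward compound 1, with the step of a 1.8-fold lower number from compound 2 to compound 3 (0.27 log units; within the scatter) estimated as a modest drop that may not exceed the scatter. Compound 3 is therefore estimated at 12000 nM, within a range from 4000 nM to 40000 nM.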

Compound 3, concentration for 50% growth inhibition: > 100000 nM
Compound 3: a limit, no number (the forecaster's own chance of this, stated with the estimate: 10%); middle value at least 8.3-fold (0.92 log units) from the limit.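

In this assay, tert-butyl in place of benzyl on a saturated ring carbon of the five-membered non-aromatic ring with 2 nitrogen gives an at least 4.5-fold higher number from compound 2 to compound 3 (0.65 log units; beyond the scatter). This step rests on a limit and not on a number: the limit of > 100000 nM in this assay, at which 1 of the 3 values shown sits. The two earlier compounds could not show how this position responds to a single change of group, whereas this pair shows that the group it carries matters in this assay, and that going from benzyl to tert-butyl, with fewer heavy atoms and no ring, does not by itself bring the number down.

The compounds shown leave open whether the outcome follows from losing the aromatic ring of benzyl or from bringing in the branched tert-butyl, and how far compound 3 truly lies from compound 2. Going by these compounds, what a longer unbranched chain, an isobutyl group or an amine would give on this saturated ring carbon also remains open, so no trend can be drawn for this position from one pair.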